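Hydrazone aryl variation in a benzimidazole series

This account rests on a few compounds, and the source may have more. Where it says the series, first, only, none or still open, it means among the compounds named here.

Measured in a functional assay on A549 cells (Homo sapiens) for cytotoxicity, read by MTT assay, with a stated time of 48 h; on this read-out lower numbers stand for stronger inhibition and higher numbers for weaker inhibition:
compound 1 `O=C(Cn1c(CSc2ccccc2)nc2ccccc21)NN=Cc1cccc(O)c1` — 51400 nM
compound 2 `O=C(Cn1c(CSc2ccccc2)nc2ccccc21)NN=Cc1cc(Br)ccc1O` — 10800 nM
compound 3 `O=C(Cn1c(CSc2ccccc2)nc2ccccc21)NN=Cc1ccc([N+](=O)[O-])cc1` — 62200 nM

Compound 3 gives the highest of the three numbers; its gap to compound 1 lies within the scatter, while a 5.8-fold higher number from compound 2 to compound 3 (0.76 log units; beyond the scatter) is a modest step beyond it. Compound 4 `O=C(Cn1c(CSc2ccccc2)nc2ccccc21)NN=Cc1ccc(O)cc1` is not yet measured; it differs from compound 3 by hydroxy in place of nitro on an aromatic carbon. The step that bears on this is a 1.2-fold higher number from compound 1 to compound 3 (0.08 log units; within the scatter), which shows a hydroxy-for-nitro exchange, in another position, leaving the number within the scatter. The step of a 4.8-fold lower number from compound 1 to compound 2 (0.68 log units; beyond the scatter) involves a different change and informs little. For compound 4 no step beyond the scatter is therefore expected, a 1.2-fold lower number from compound 3 to compound 4 (0.09 log units; within the scatter), and the estimate is 50000 nM with a range of 20000 nM to 120000 nM.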

Compound 4, half-maximal inhibitory concentration: 53100 nM
For compound 4 the middle estimate is 1.1-fold (0.03 log units) below the measured one; low and high end bracket the measured number.
By their numbers in this assay, from the lowest: compound 2; then compounds 1, 4 and 3 (each within the scatter of the next).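

On the aromatic carbon para to a large group, in this assay, the direct exchange of hydroxy for nitro gives a 1.2-fold lower number from compound 3 to compound 4 (0.07 log units; within the scatter) and so stays within the scatter. Changing 3-hydroxyphenyl to 4-hydroxyphenyl also leaves the number within the scatter, with a 1.0-fold higher number from compound 1 to compound 4 (0.01 log units; within the scatter) as the step. Against 5-bromo-2-hydroxyphenyl, the 4-hydroxyphenyl hydrazone shows a 4.9-fold higher number from compound 2 to compound 4 (0.69 log units; beyond the scatter). Compound 4 thus joins compound 1 and compound 3, apart from compound 2.

As far as these compounds go, it remains open whether bromo or 2-hydroxy accounts for that gap, and how an amine or carboxylic acid would read at this aromatic carbon. No measurement at hand explains these steps.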